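Carrying a Known Ring Swap onto a Fluorinated Core

This account rests on a few compounds, and the source may have more. Where it says the series, first, only, none or still open, it means among the compounds named here.

Compound 1, `O=C(Nc1ccc(Oc2ccnc3[nH]ccc23)cc1)c1nn(-c2ccccc2)ccc1=O`, gives 15000 nM in a functional assay on PC-3 cells (Homo sapiens) for cytotoxicity, read by MTT assay, with a stated time of 72 h; a lower number here means a stronger inhibitor, a higher number a weaker inhibitor.
Compound 2, `O=C(Nc1ccc(Oc2ccnc3[nH]ccc23)cc1)c1nn(-c2ccc(Br)cc2F)ccc1=O`, gives 12800 nM in this assay.
Compound 3, `O=C(Nc1ccc(Oc2ccnc3[nH]ccc23)c(F)c1)c1nn(-c2ccccc2)ccc1=O`, gives 38600 nM in this assay.

Of the compounds shown here, three built on one shared core have been measured in this assay. Compound 1 and compound 2 differ at a single place: 4-bromo-2-fluorophenyl in place of phenyl on an aromatic nitrogen. That change gave a 1.2-fold lower number from compound 1 to compound 2 (0.07 log units; within the scatter), so the two numbers cannot be told apart. Compound 3 differs from compound 1 at another place on the core: fluoro in place of hydrogen on an aromatic carbon. Here the change gave a 2.6-fold higher number from compound 1 to compound 3 (0.41 log units; beyond the scatter), and compound 3 carries the highest number of the three, with its distance to compound 2 also beyond the scatter.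

Compound 4, `O=C(Nc1ccc(Oc2ccnc3[nH]ccc23)c(F)c1)c1nn(-c2ccc(Br)cc2F)ccc1=O`, has not yet been measured. It stands to compound 3 as compound 2 stands to compound 1: 4-bromo-2-fluorophenyl in place of phenyl on an aromatic nitrogen. The place described for this change is the same, word for word, as for the change from compound 1 to compound 2, so it is the same change, made on the core of compound 3 instead of the core of compound 1. Among the measured compounds shown here, in its one earlier example the change produced nothing that rose above the scatter. The expectation is therefore that compound 4 will sit close to compound 3, with a step estimated at a 1.2-fold lower number from compound 3 to compound 4 (0.08 log units; within the scatter), because the same change gave a 1.2-fold lower number from compound 1 to compound 2 (0.07 log units; within the scatter). With only a single prior case, a larger move in either direction cannot be ruled out. Compound 4 is estimated at 32000 nM in this assay, expected to lie between 15000 nM and 70000 nM.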

Compound 4, half-maximal inhibitory concentration: 8800 nM
Beside the measured number, compound 4's estimate is 3.6-fold (0.56 log units) above it; measured number outside the range, below it.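

In this assay, the swap of phenyl for 4-bromo-2-fluorophenyl did not carry over at the same size: on the fluorinated core it gave a 4.4-fold lower number from compound 3 to compound 4 (0.64 log units; beyond the scatter), a clear step where the earlier example had shown none that could be told from the scatter, and the two results differ: the same change on two cores in this assay, a 1.2-fold lower number (0.07 log units; within the scatter) from compound 1 to compound 2 and a 4.4-fold lower number (0.64 log units; beyond the scatter) from compound 3 to compound 4, 3.7-fold (0.57 log units) apart, beyond the scatter of two such steps. Read the other way, the fluoro on the shared core also depends on what sits on the aromatic nitrogen: with 4-bromo-2-fluorophenyl there, it gave a 1.5-fold lower number from compound 2 to compound 4 (0.16 log units; within the scatter), so the rise in the number seen with phenyl does not appear, and these two results differ as well: the same change on two cores in this assay, a 2.6-fold higher number (0.41 log units; beyond the scatter) from compound 1 to compound 3 and a 1.5-fold lower number (0.16 log units; within the scatter) from compound 2 to compound 4, 3.7-fold (0.57 log units) apart, beyond the scatter of two such steps. These four compounds therefore show that the two changes do not simply add up in this assay, but they form only one such set, so they cannot explain the mismatch or show that it would hold on any other core.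

The compounds shown leave open whether the bromine or the fluorine of the new ring is responsible, since the two only ever appear together, and a phenyl carrying just one of them would separate them. They also leave open how a chloro or a methoxy group would behave at the fluoro position on the core.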